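A few compounds are considered here, and "the series" means these few. Any claim that something is new, unique, unknown or untested is made for them only; others in the source may bear on it.

Of the compounds shown here, three built on one shared core have been tested in a functional assay on the whole organism (Tail, strain ICR) with Mus musculus as the target, in the tail flick test, with a stated time of 60 min, at a dose of 25 umol/kg by the oral route (a lower number here means a weaker effect, a higher number a stronger effect of the compound at the dose given), which reports how much of the possible effect appears at a single fixed dose. Compound 3 `O=C(CN(c1ncnc2c1ncn2C1CCCCO1)C1CC1)N[C@@H](CC(=O)OCc1ccccc1)C(=O)OCc1ccccc1` gives 38.2% in this assay. Compound 1 `O=C(CN(c1ncnc2c1ncn2C1CCCCO1)C1CC1)N[C@@H](CCC(=O)OCc1ccccc1)C(=O)OCc1ccccc1` gives 34.7%, and compound 2 `C[C@@H](O)[C@H](NC(=O)CN(c1ncnc2c1ncn2C1CCCCO1)C1CC1)C(=O)OCc1ccccc1` gives 28.4%. On these numbers compound 3 holds the highest value, yet every gap to it lies within the usual scatter: a number 3.5 percentage points higher from compound 1 to compound 3 (within the scatter) and a number 9.8 percentage points higher from compound 2 to compound 3 (within the scatter). The gap between the other two, a number 6.3 percentage points lower from compound 1 to compound 2 (within the scatter), is also within the scatter, so the three compounds cannot be told apart by this assay.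

Compound 4 `CC(C)(C)OC(=O)NCCCC[C@H](NC(=O)CN(c1ncnc2c1ncn2C1CCCCO1)C1CC1)C(=O)OCc1ccccc1` has not been measured yet. It differs from compound 3 at the side chain that hangs from the amino acid part of the molecule: 3-((tert-butoxycarbonyl)amino)propyl in place of benzyloxycarbonyl on a saturated chain carbon, two bonds along the chain from an amide-type nitrogen and a carbonyl carbon. All three measured steps change this same side chain, and none of them moved the number beyond the scatter. On that basis the expectation is that the step to compound 4 will also be small, with no direction beyond the scatter, as a number 4.2 percentage points lower from compound 3 to compound 4 (within the scatter). The expected value for compound 4 is therefore 34%, estimated to lie between 16% and 52%.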

Compound 4, a percentage reported as activity, at one dose (the size of the read-out at that dose, not a potency): 32.7%
The estimate for compound 4 lay 1.3 percentage points above the measured number; measured number inside the range.
By their numbers in this assay, from the lowest: compounds 2, 4, 1 and 3 (each within the scatter of the next).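

In this assay, the change at this saturated chain carbon, with 3-((tert-butoxycarbonyl)amino)propyl in place of benzyloxycarbonyl, gives a number 5.5 percentage points lower from compound 3 to compound 4 (within the scatter) and so adds a new kind of side chain to the series: one with no ring, 1 hydrogen-bond donor and a protected nitrogen. Set against the other two measured compounds, the same side chain gives a number 4.3 percentage points higher from compound 2 to compound 4 (within the scatter) and a number 2 percentage points lower from compound 1 to compound 4 (within the scatter), so none of the steps among these four compounds separates the side chains, even with this nitrogen-bearing chain included. No measurement is available that could explain this flat picture.

The compounds shown leave open whether a free amine at the end of the butyl chain, or a carboxylic acid in place of a benzyl ester, would move the number beyond the scatter. They also leave open whether side chains that read alike at this one dose would still do so at other doses, as a single-dose read-out gives the size of the effect and not a potency.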